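The source may report more compounds than this note shows. Statements on the series, on what has been measured and on what is new or still open speak of the compounds shown alone.

Measured in a functional assay on cells (Platelet, Homo sapiens) for inhibition; on this read-out higher numbers stand for weaker inhibition and lower numbers for stronger inhibition:
- Compound 1 `CCOC(=O)c1ccc(-c2nn(Cc3ccc(F)cc3)c3ccccc23)cc1`: 190 nM
- Compound 2 `O=C(O)c1ccc(-c2nn(Cc3ccccc3)c3ccccc23)cc1`: > 10000 nM, a limit of the assay

Compound 2 stands at the limit of > 10000 nM in this assay, at which 1 of the 2 values shown sits, so it has a limit and not a number. Going by the values given here, compounds 1 and 2 differ in more than one place, and no measured pair isolates a single change.

Compound 3 `CNC(=O)c1ccc(-c2nn(Cc3ccccc3)c3ccccc23)cc1` keeps the shared core of compound 2 and has methylamino in place of hydroxy on a carbonyl carbon, so carboxy becomes methylcarbamoyl: methylamino in place of hydroxy on a carbonyl carbon.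

The expectation rests on compound 1, which has no carboxy and gives 190 nM in this assay. This is only a loose guide, since compound 1 differs in other ways too. The expected change, an at least 5.0-fold lower number from compound 2 to compound 3 (0.69 log units; beyond the scatter), is toward stronger inhibition, and its size is uncertain. The estimate for compound 3 is 2000 nM, with an expected range of 300 nM to 10000 nM.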

Compound 3, half-maximal inhibitory concentration: > 10000 nM
Compound 3: a limit, no number; the forecaster's own chance of this, stated with the estimate: 25%; middle value at least 5.0-fold (0.69 log units) away from the limit.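

Going by these compounds alone, compound 2 and compound 3 both sit at a limit of the assay rather than at a number, so no step between them can be read: the limit of > 10000 nM in this assay, at which 2 of the 3 values shown sit. As far as these compounds go, whether methylcarbamoyl and carboxy differ at all in this assay stays open.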